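The compounds below may be only part of what the source reports. "The series", "measured", "known", "first", "only" and "open" are said of these compounds alone.

Of the compounds shown here, two with a shared core have been measured. Compound 1 `CC(C)c1cccc(OCc2cccc(N3C(N)=NC(N)=NC3(C)C)c2)c1` carries a long substituent on the outer ring and, in a functional assay on L5178Y cells (Mus musculus) for inhibition (a lower number here means a less potent compound, a higher number a more potent compound, by a factor of ten per unit of this negative logarithm), compound 1 gives 8.13. Compound 2 `CC1(C)N=C(N)N=C(N)N1c1cccc(C(O)c2ccccc2)c1` is the weaker of the pair: in this assay compound 2 gives 6.41, the lowest of the two values and well beyond the scatter from compound 1. Compound 3 `CC(=O)c1cccc(N2C(N)=NC(N)=NC2(C)C)c1` has not been measured yet. It differs from compound 2 in one place: acetyl in place of hydroxy(phenyl)methyl on an aromatic carbon. For the measured compounds named here, no measured pair shows this exact step, so the direction is uncertain; since compound 2 already sits at the low end with 6.41, the replacement of a larger group by a smaller one is expected to bring a modest further loss, perhaps no larger than the scatter, with an expected step of a number 0.31 log units lower from compound 2 to compound 3 (beyond the scatter). Compound 3 is therefore estimated at 6.1 in this assay, with a likely range from 5.4 to 6.8.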

Compound 3, logarithm of the reciprocal of the active concentration, log(1/C): 6.96
Estimate against measurement, compound 3: 0.86 log units below; the measured number lies above the stated range.
By their numbers in this assay, from the lowest: compound 2; then compound 3; then compound 1.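

In this assay, acetyl in place of hydroxy(phenyl)methyl on this aromatic carbon gives a number 0.55 log units higher from compound 2 to compound 3 (beyond the scatter), so the outer six-membered aromatic ring of compound 2 and its larger size are not needed here to hold this level of potency. The smaller group, with no ring and no hydrogen-bond donor, does better at this place than the larger one, and size alone therefore does not set the order at this position. Nothing available gives a measured reason for this step.

The change removes the ring and the hydroxyl and introduces the carbonyl all at once, and the compounds shown do not separate these. Benzoyl, which keeps the ring with a carbonyl, or hydroxymethyl, which keeps the hydroxyl without the ring, would bear on that question.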